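Adding a Hydroxy Group to Compound 1

A few compounds are considered here, and "the series" means these few. Any claim that something is new, unique, unknown or untested is made for them only; others in the source may bear on it.

In a functional assay with Rattus norvegicus as the target (on this read-out higher numbers stand for an effect only at larger amounts of compound and lower numbers for an effect already at smaller amounts), compound 1 `CCCCCCCCC(=O)NCc1cccc(OC)c1` gives > 100000 nM, which is a limit of the assay and not a number. Compound 2 `CCCCCCCCC(=O)NCc1ccc(OC)cc1` gives > 100000 nM, again a limit. Compound 3 `CCCCCCCCC(=O)NCc1ccccc1OC` gives > 100000 nM, also a limit. All that can be said of where compound 1 stands is therefore (the limit of > 100000 nM in this assay, at which 3 of the 3 values shown sit). Among the compounds with values here, none of the three compounds has a number of its own, and no step between measured compounds is available to show how far a single change moves the read-out.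

Compound 4 `CCCCCCCCC(=O)NCc1cc(O)cc(OC)c1` has not yet been measured. It differs from compound 1 by one change: hydroxy in place of hydrogen on an aromatic carbon, meta to a large group and meta to a methoxy group. The expectation rests on compound 1 with its limit of > 100000 nM, and the data offer no measured ground for a large move. The expected change, a number no higher from compound 1 to compound 4 (the limit leaves the size open), is none beyond the scatter, and this assay will most likely report only a limit again. Compound 4 is estimated at 100000 nM, with an expected range from 30000 nM to 300000 nM.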

Compound 4, half-maximal effective concentration: > 100000 nM
Compound 4: a limit, no number; the forecaster's own chance of this, stated with the estimate: 80%; the middle value sits exactly at the limit.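

Compound 1 and compound 4 both stand at a limit in this assay, so the step from hydroxy in place of hydrogen on an aromatic carbon cannot be read. The compounds shown leave open which change to the shared core, if any, would yield an actual number in this assay, as none has one: the limit of > 100000 nM in this assay, at which 4 of the 4 values shown sit.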